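Chromene hydroxyureas: methyl to phenyl at the ring carbon

A few compounds are considered here, and "the series" means these few. Any claim that something is new, unique, unknown or untested is made for them only; others in the source may bear on it.

Measured so far in an assay (Cavia porcellus) for inhibition of Polyunsaturated fatty acid 5-lipoxygenase (Homo sapiens); a higher number here means a weaker inhibitor, a lower number a stronger inhibitor:
- compound 1, `CC1Oc2ccc(OCc3ccccc3)cc2C=C1CN(O)C(N)=O`: 220 nM
- compound 2, `CC1Oc2ccc(Oc3ccccc3)cc2C=C1CN(O)C(N)=O`: 120 nM

Compound 2 gives the lowest of the two numbers in this assay; its nearest neighbour is compound 1, and the step of a 1.8-fold lower number from compound 1 to compound 2 (0.26 log units; within the scatter) is within the scatter, so the two cannot be ordered on these numbers.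

Compound 3, `NC(=O)N(O)CC1=Cc2cc(Oc3ccccc3)ccc2OC1c1ccccc1`, differs from compound 2 in one place: phenyl in place of methyl on a saturated ring carbon. The change sits on a saturated ring carbon of a six-membered non-aromatic ring with 1 oxygen, next to the ring oxygen and next to the ring atom that bears the (carbamoyl(hydroxy)amino)methyl group.

Among the measured compounds shown here, no measured step touches this position; the only step in hand, from compound 1 to compound 2, concerns the group on the aromatic oxygen and was within the scatter. For the measured compounds named here, the data therefore give no direction for the step from compound 2 to compound 3 in this assay, and the expectation is no change beyond the scatter, with wide uncertainty.

For compound 3 the estimate in this assay is 150 nM, range 40 nM to 600 nM, an expected step of a 1.3-fold higher number from compound 2 to compound 3 (0.10 log units; within the scatter).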

Compound 3, half-maximal inhibitory concentration: 310 nM
The estimate for compound 3 lay 2.1-fold (0.32 log units) below the measured number; the range from low to high includes it.
By their numbers in this assay, from the lowest: compounds 2, 1 and 3 (each within the scatter of the next, the first and the last beyond it).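

In this assay, among the compounds shown here, the saturated ring carbon next to the ring oxygen now has its first reading: phenyl in place of methyl gives a 2.6-fold higher number from compound 2 to compound 3 (0.41 log units; beyond the scatter), a modest step and the only one so far that lies beyond the scatter. The change brings in a six-membered aromatic ring and six heavy atoms where methyl had one, yet compound 3 still gives 310 nM, so this position tolerates phenyl with a modest rise in the number rather than a loss of inhibition on the scale of this series. Nothing at hand accounts for the direction or the size of this step.

As far as these compounds go, it remains open whether the step belongs to phenyl itself or would follow from other groups at this carbon; ethyl, cyclohexyl, or a phenyl ring carrying an amine or a carboxylic acid would help separate those readings. From the compounds shown here alone, it is also open whether phenyl in place of methyl gives a similar step when benzyl rather than phenyl sits on the oxygen on the aromatic ring.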